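The compounds below may be only part of what the source reports. "The series", "measured", "known", "first", "only" and "open" are said of these compounds alone.

Two compounds share the same core and differ only in the ring attached to a carbon with a double bond to nitrogen. Compound 1 `CN(C)CCn1cnnc1-c1cc(Oc2ccc(NC(=O)N/N=C/c3ccc(F)cc3F)cc2F)ccn1` carries a 2,4-difluorophenyl there, and in an ADME assay on WI-38 cells (Homo sapiens) for cytotoxicity, read by MTT assay, with a stated time of 72 h (on this read-out lower numbers stand for stronger inhibition and higher numbers for weaker inhibition), compound 1 gives 5030 nM. For the measured compounds named here, compound 2 `CN(C)CCn1cnnc1-c1cc(Oc2ccc(NC(=O)N/N=C/c3ccc(Cl)cc3)cc2F)ccn1` carries a 4-chlorophenyl instead, and in this assay compound 2 gives 1870 nM, the lowest of the two numbers known so far; the only measured step is a 2.7-fold lower number from compound 1 to compound 2 (0.43 log units; beyond the scatter). Compound 3 `Cc1cc(/C=N/NC(=O)Nc2ccc(Oc3ccnc(-c4nncn4CCN(C)C)c3)c(F)c2)cc(C)c1O` is the next change from compound 2: 4-hydroxy-3,5-dimethylphenyl in place of 4-chlorophenyl on a carbon with a double bond to nitrogen. Going by the values given here, no measured step tests this kind of exchange; the single measured step shows only that swapping the ring at this position can move the number modestly. For compound 3 the step of a 1.6-fold higher number from compound 2 to compound 3 (0.21 log units; within the scatter) is therefore expected to be small, with no clear direction. Compound 3 is estimated at 3000 nM, with a likely range from 1000 nM to 10000 nM.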

Compound 3, half-maximal inhibitory concentration: 3610 nM
For compound 3 the middle estimate is 1.2-fold (0.08 log units) below the measured one; the measured number falls inside the stated range.
By their numbers in this assay, from the lowest: compounds 2, 3 and 1 (each within the scatter of the next, the first and the last beyond it).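

Swapping the 4-chlorophenyl for 4-hydroxy-3,5-dimethylphenyl at this position gives a 1.9-fold higher number from compound 2 to compound 3 (0.29 log units; within the scatter) in this assay, while swapping the 2,4-difluorophenyl for the same ring gives a 1.4-fold lower number from compound 1 to compound 3 (0.14 log units; within the scatter). Compound 3 therefore cannot be told apart from either earlier compound, even though its ring has a hydrogen-bond donor and acceptor that the two halogen-bearing rings lack, and the step between compound 1 and compound 2 remains the only one beyond the scatter. No supporting measurement is available to explain these numbers.

From the compounds shown here alone, compound 3 changes the hydroxy and the two methyl groups together, so their separate contributions remain unknown. Going by these compounds, it is also open whether a ring bearing an amine or a carboxylic acid at this position would move the number beyond the scatter.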